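The source may report more compounds than this note shows. Statements on the series, on what has been measured and on what is new or still open speak of the compounds shown alone.

Measured in a functional assay on cells (Hepatocyte, Rattus norvegicus) for inhibition, read by scintillation counting, with a stated time of 4 h; on this read-out higher numbers stand for weaker inhibition and lower numbers for stronger inhibition:
- compound 1 `Cc1ccccc1CNC(=O)c1nc(-c2ccc(F)cc2)n(CC[C@@H](O)C[C@@H](O)CC(=O)O)c1C1CC1`: 0.1 nM
- compound 2 `COc1ccc(CNC(=O)c2nc(-c3ccc(F)cc3)n(CC[C@@H](O)C[C@@H](O)CC(=O)O)c2C2CC2)cc1F`: 0.2 nM
- compound 3 `COc1ccc(CNC(=O)c2nc(-c3ccc(F)cc3)n(CC[C@@H](O)C[C@@H](O)CC(=O)O)c2C2CC2)cc1`: 0.2 nM

Compound 3 stands level with compound 2 at the digits shown, and compound 1 lies within the usual scatter of both. The next compound, compound 4 `COc1cccc(CNC(=O)c2nc(-c3ccc(F)cc3)n(CC[C@@H](O)C[C@@H](O)CC(=O)O)c2C2CC2)c1`, has 3-methoxyphenyl in place of 4-methoxyphenyl on a saturated chain carbon bound to an amide-type nitrogen. The two compounds have the same atoms, joined differently: 3-methoxyphenyl in place of 4-methoxyphenyl on a saturated chain carbon bound to an amide-type nitrogen.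

For the measured compounds named here, three measured steps bear on this change. Putting 4-methoxyphenyl in place of 2-methylphenyl gave a 2.0-fold higher number from compound 1 to compound 3 (0.30 log units; within the scatter). Putting 3-fluoro-4-methoxyphenyl in the same place gave a 2.0-fold higher number from compound 1 to compound 2 (0.30 log units; within the scatter). Replacing fluoro with hydrogen on the aromatic ring gave no change at the digits printed from compound 2 to compound 3 (within the scatter). All three stayed within the scatter, so the changes tried on this ring have not yet produced a clear shift. Going by the values given here, no measured pair compares 3-methoxyphenyl with 4-methoxyphenyl directly, however, so the expectation rests on indirect evidence and the range has to stay fairly wide.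

The step expected in this assay is no change at the digits printed from compound 3 to compound 4 (within the scatter), with no direction beyond the scatter anticipated. For compound 4 the estimated value is 0.2 nM, with an expected range from 0.08 nM to 0.6 nM.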

Compound 4, half-maximal inhibitory concentration: 0.2 nM
Beside the measured number, compound 4's estimate shows no gap at the digits printed; the range from low to high includes it.
By their numbers in this assay, from the lowest: compounds 1, 2, 3 and 4 (each within the scatter of the next).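

In this assay, for the compounds shown here, the direct exchange of 4-methoxyphenyl for 3-methoxyphenyl on the saturated chain carbon bound to the amide-type nitrogen gives no change at the digits printed from compound 3 to compound 4 (within the scatter), which is the first head-to-head reading of these two methoxyphenyl groups. The two other new comparisons agree: 3-methoxyphenyl in place of 3-fluoro-4-methoxyphenyl gives no change at the digits printed from compound 2 to compound 4 (within the scatter), and 3-methoxyphenyl in place of 2-methylphenyl gives a 2.0-fold higher number from compound 1 to compound 4 (0.30 log units; within the scatter). All four groups shown at this place therefore read within the scatter of one another, so this read-out separates none of them, and no further evidence bears on why that is so.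

As far as these compounds go, it remains open whether a clear shift would appear with a very different group at this place, such as a phenyl ring carrying an amine or a carboxylic acid, or with a longer chain between the ring and the amide-type nitrogen. From the compounds shown here alone, how these four compounds would compare in any other kind of test also remains open, as the values here cannot speak to that.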